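Swapping Chloro for Bromo in a Receptor Binding Series

The source may report more compounds than this note shows. Statements on the series, on what has been measured and on what is new or still open speak of the compounds shown alone.

Compound 3 `CCN(CC)c1cc(C)nc(N(CC)c2c(Cl)cc(OC)cc2OC)n1` stands second highest of three numbers in an assay on isolated protein for binding affinity to corticotropin-releasing factor receptor 1 (Homo sapiens) (on this read-out higher numbers stand for weaker inhibition and lower numbers for stronger inhibition), giving 10 nM. The nearest number belongs to compound 1 `CCCN(CCC)c1nc(C)nc(N(CC)c2ccc(N(C)C)cc2C)n1`, which gives 7 nM; the furthest belongs to compound 2 `CCN(CC)c1cc(C)nc(N(CC)c2c(Cl)cc(OC)cc2Cl)n1`, which gives 15 nM, and both gaps lie within the scatter. Among the compounds with values here, the one measured step, a 1.5-fold lower number from compound 2 to compound 3 (0.18 log units; within the scatter), came from a methoxy in place of chloro on an aromatic carbon. Compound 4 `CCN(CC)c1cc(C)nc(N(CC)c2c(Br)cc(OC)cc2OC)n1` differs from compound 3 by bromo in place of chloro on an aromatic carbon. Within the data shown here, no measured step swaps one halogen for another, and the single step touching this position stayed within the scatter. The step of no change at the digits printed from compound 3 to compound 4 (within the scatter) is therefore expected to stay within the scatter. Compound 4 is estimated at 10 nM, with a range from 5 nM to 20 nM.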

Compound 4, inhibition constant: 48 nM
Estimate against measurement, compound 4: 4.8-fold (0.68 log units) below; measured number outside the range, above it.
By their numbers in this assay, from the lowest: compounds 1, 3 and 2 (each within the scatter of the next, the first and the last beyond it); then compound 4.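

Within the data shown here, the aromatic carbon carrying this halogen tolerates less change than the earlier compounds suggested: in this assay, bromo in place of chloro gave a 4.8-fold higher number from compound 3 to compound 4 (0.68 log units; beyond the scatter). The earlier replacement of a chloro by methoxy, a 1.5-fold lower number from compound 2 to compound 3 (0.18 log units; within the scatter), stayed within the scatter, so a swap between two halogens here moved the number further than that change did. Nothing available here accounts for this difference.

Still open, from the compounds shown here alone, is whether a smaller group here, such as fluoro or methyl, would stay close to chloro or shift the number as bromo does.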